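Adding a 4-Bromophenyl Group: From Compound 2 to Compound 4

This account rests on a few compounds, and the source may have more. Where it says the series, first, only, none or still open, it means among the compounds named here.

Compound 1 `O=C(CCCCC1CCSS1)NCc1cn(CCCCOc2ccc3ccc(=O)oc3c2)nn1` gives 69.8% in a functional assay on PC-12 cells (Rattus norvegicus) for cytotoxicity, read by MTT assay, with stated times of 3 h and 2 h, tested at 20 uM; a lower number here means a weaker effect, a higher number a stronger effect of the compound at the concentration tested.
Compound 2 `O=C(CCCCC1CCSS1)NCc1cn(CCCCCOc2ccc3ccc(=O)oc3c2)nn1` gives 78.5%.
Compound 3 `Cc1cc(=O)oc2cc(OCCCCCn3cc(CNC(=O)CCCCC4CCSS4)nn3)ccc12` gives 70.3%.

Of the three measured compounds, compound 2 carries the highest number, but its lead over compound 3 and over compound 1 lies within the usual scatter, so the three cannot be told apart on these data. For the measured compounds named here, the only measured change at a single place is methyl in place of hydrogen on an aromatic carbon, which gave a number 8.2 percentage points lower from compound 2 to compound 3 (within the scatter).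

Compound 4 `O=C(CCCCC1CCSS1)NCc1cn(CCCCCOc2ccc3cc(-c4ccc(Br)cc4)c(=O)oc3c2)nn1` is compound 2 with 4-bromophenyl in place of hydrogen on an aromatic carbon. Going by the values given here, no measured step involves a change of this kind. Among the compounds with values here, the one step at hand, the methyl for hydrogen just described, stayed within the scatter, and it concerns a much smaller group than the 4-bromophenyl, so it offers only weak guidance. Nothing in the data points in either direction. The expected step is therefore one that does not go beyond the scatter, written as a number 1.5 percentage points lower from compound 2 to compound 4 (within the scatter), with a broad range to mark the untested nature of the change. Compound 4 is estimated at 77%, with a range from 60% to 92%.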

Compound 4, a percentage reported as activity, at one concentration (the size of the read-out at that concentration, not a potency): 52.3%
Compound 4: the middle estimate sits 24.7 percentage points above what was measured, and the stated range ends above it.
By their numbers in this assay, from the lowest: compound 4; then compounds 1, 3 and 2 (each within the scatter of the next).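

In this assay, for the compounds shown here, this carbon of the shared core, two atoms from the ring oxygen, proves sensitive to substitution: 4-bromophenyl in place of hydrogen gives a number 26.2 percentage points lower from compound 2 to compound 4 (beyond the scatter), the only single-place change here to go beyond the scatter. The earlier methyl step could not show this, as it stayed within the scatter and brought in a single carbon, whereas this change adds an aromatic ring and a bromine, 7 heavy atoms in all, and the lower number means a weaker effect at the concentration tested. No measurement at hand accounts for this fall.

Going by these compounds, a single substituent cannot separate the contribution of the aromatic ring from that of the bromine, so it remains open whether plain phenyl, 4-chlorophenyl or 4-methoxyphenyl at this carbon would behave like 4-bromophenyl, and whether methyl here would leave the number unmoved. Also open, on these data alone, is whether 4-bromophenyl would produce a similar step on the shorter chain of compound 1, or alongside the methyl of compound 3.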